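In vivo dose-response across four benzothiazole-type compounds

The compounds below may be only part of what the source reports. "The series", "measured", "known", "first", "only" and "open" are said of these compounds alone.

The set comprises three measured compounds and one awaiting measurement, all tested in a functional assay on the whole organism with Rattus norvegicus as the target; on this read-out higher numbers stand for an effect only at larger amounts of compound and lower numbers for an effect already at smaller amounts. Compound 1, with the structure `CC(C)(C)Oc1ccc2nc(N)sc2c1`, gives in this assay a value of > 10 mg/kg, which is a limit of the assay rather than a number. Compound 2, with the structure `CCCCCCCc1ccc2nc(N)sc2c1`, likewise gives > 10 mg/kg, again a limit and not a measured number. Compound 3, with the structure `N=c1sc2cc(OC(F)(F)F)ccc2n1CC(N)=O`, is the only one of the three to return an actual number, giving 7 mg/kg in this assay. Its place among the values shown is therefore defined by the limit of > 10 mg/kg in this assay, at which 2 of the 3 values shown sit, while compound 3 alone falls inside the measurable range.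

Compound 4, with the structure `CS(=O)(=O)CCCn1c(=N)sc2cc(OC(F)(F)F)ccc21`, differs from compound 3 by 2-(methylsulfonyl)ethyl in place of carbamoyl on a saturated chain carbon bound to an aromatic nitrogen. No pair of measured compounds differing in a single place is available, so the size of this step cannot be read from the shown data. The expected step from compound 3 to compound 4 in this assay is no change at the digits printed from compound 3 to compound 4 (within the scatter), that is, no change beyond the usual scatter. Compound 4 is accordingly estimated to give 7 mg/kg in this assay, with an expected range from 2.5 mg/kg to 20 mg/kg.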

Compound 4, dose for half-maximal effect: 5 mg/kg
Compound 4: middle estimate off by 1.4-fold (0.15 log units), on the high side, within the range that was stated.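

At the saturated chain carbon bound to an aromatic nitrogen, 2-(methylsulfonyl)ethyl in place of carbamoyl gives, in this assay, a 1.4-fold lower number from compound 3 to compound 4 (0.15 log units; within the scatter), which is the first step at this position that can be read from the compounds shown. The change is not a small one in what is counted: carbamoyl, with 3 heavy atoms and 1 hydrogen-bond donor, gives way to a group with 6 heavy atoms and 0 hydrogen-bond donors, and the read-out still stays within the scatter, so neither the amide hydrogen nor the shorter group proves necessary here for an effect on this scale. No measured property among the data shown bears on this step, so it stands without an explanation.

The compounds shown leave open whether a carboxylic acid, an amine or a much longer chain at this position would also stay within the scatter, since a single step cannot show how far this tolerance extends. Compound 1 and compound 2 differ from compound 3 in more than one place and so add nothing about this position.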